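The compounds below may be only part of what the source reports. "The series", "measured", "known", "first", "only" and "open" are said of these compounds alone.

Compound 2, `CCOCc1c(C)coc1-c1ccc2c(c1OC)CCCC2(C)C`, is examined in a functional assay on A549 cells (Homo sapiens) for cytotoxicity, read by sulforhodamine B assay, with a stated time of 3 days (a higher number here means that more compound is needed for the effect, a lower number that less compound is needed), where it gives 22.9 uM. That places compound 2 level, at the digits recorded, with compound 1, `CCOc1c(-c2occ(C)c2CO)ccc2c1CCCC2(C)C`, which in this assay gives 22.9 uM; the two stand together at the lowest end of the three numbers observed. Compound 3, `Cc1coc(-c2ccc3c(c2O)CCC3)c1C(=O)O`, gives 41.5 uM in this assay, a difference from compound 2 that remains within the scatter of repeated measurement. Compound 4, `COc1c(-c2occ(C)c2COC(C)=O)ccc2c1CCCC2(C)C`, has not yet been measured. It differs from compound 2 in one place: acetyl in place of ethyl on an oxygen on a saturated carbon. With compound 1 and compound 2 reading alike despite differing at this same oxygen, the step from compound 2 to compound 4 is expected to stay within the scatter, estimated as a 1.1-fold lower number from compound 2 to compound 4 (0.04 log units; within the scatter). Compound 4 is therefore expected to give 21 uM in this assay, within a range of 9 uM to 50 uM.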

Compound 4, concentration for half-maximal effect: 28.7 uM
Compound 4: the middle estimate sits 1.4-fold (0.14 log units) below what was measured; measured number inside the range.
By their numbers in this assay, from the lowest: compounds 1, 2, 4 and 3 (each within the scatter of the next).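

In this assay, acetyl in place of ethyl on an oxygen on a saturated carbon gives a 1.3-fold higher number from compound 2 to compound 4 (0.10 log units; within the scatter). This is the first pair among these compounds that differs in one place alone, and it shows that this exchange, which brings in a hydrogen-bond acceptor, does not move the reading beyond the scatter. No measurement shown here speaks to the reason for this result.

Going by these compounds, whether an amine or a longer chain in this place would also read alike remains open. So does whether any group here can move the reading beyond the scatter.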